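Cyanoguanidine series: alkyl branching and minimum effective dose

The source may report more compounds than this note shows. Statements on the series, on what has been measured and on what is new or still open speak of the compounds shown alone.

Measured so far:
Compound 1, `CC(C)/N=C(\NC#N)Nc1cccnc1`, in a functional assay on the whole organism (blood, strain Wistar-Okamoto) with Rattus norvegicus as the target, with a stated time of 5 days (on this read-out higher numbers stand for an effect only at larger amounts of compound and lower numbers for an effect already at smaller amounts), compound 1 gives 2.5 mg/kg.
Compound 2, `CCC(C)/N=C(\NC#N)Nc1cccnc1`, in this assay compound 2 gives 20 mg/kg.
Compound 3, `Cc1cccc(C)c1N/C(=N/C#N)NC(C)(C)C`, in this assay compound 3 gives only > 50 mg/kg, which is a limit of the assay and not a number (the limit of > 50 mg/kg in this assay, at which 1 of the 3 values shown sits).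

Within the core of compound 1, the change methyl in place of hydrogen on a saturated chain carbon, two bonds along the chain from a double-bonded nitrogen gave an 8.0-fold higher number from compound 1 to compound 2 (0.90 log units; beyond the scatter). The difference between the core of compound 1 and the core of compound 3 is not broken down here. Compound 4, `CCC(C)(C)N/C(=N\C#N)Nc1c(C)cccc1C`, not yet measured, carries the same kind of change, (methyl in place of hydrogen on a saturated chain carbon, two bonds along the chain from an amine nitrogen); the place differs in that the chain carbon lies two bonds from an amine nitrogen rather than from a double-bonded nitrogen. Beside the earlier step, a step that the limit leaves unreadable from compound 3 to compound 4 is expected for compound 4, resting on an 8.0-fold higher number from compound 1 to compound 2 (0.90 log units; beyond the scatter) and on the limit of compound 3 (the limit of > 50 mg/kg in this assay, at which 1 of the 3 values shown sits). Compound 4 is therefore estimated at 100 mg/kg, most likely again reported only as a limit.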

Compound 4, minimum effective dose: 50 mg/kg
Estimate against measurement, compound 4: 2.0-fold (0.30 log units) above; measured number inside the range.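

In this assay, methyl in place of hydrogen on a saturated chain carbon, two bonds along the chain from an amine nitrogen, gave a number no higher from compound 3 to compound 4 (the limit leaves the size open). Set beside the earlier step, the change does not carry over at the same size from one core to the other: the same change on two cores in this assay, an 8.0-fold higher number (0.90 log units; beyond the scatter) from compound 1 to compound 2 and a number no higher (the limit leaves the size open) from compound 3 to compound 4, at least 8.0-fold (0.90 log units) apart, beyond the scatter of two such steps. This does not show whether the core or the place of the change accounts for the gap, as the chain carbon lies two bonds from a double-bonded nitrogen in one pair and from an amine nitrogen in the other, and the second step has no readable size: the limit of > 50 mg/kg in this assay, at which 1 of the 4 values shown sits.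

Among the compounds shown here, each core offers only one pair. Open, on these data alone, is what a longer chain or a cyclohexyl group would give in place of these branched alkyl groups on either core.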